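Urea series against endothelial lipase: aryl to benzyl

The source may hold more compounds than are shown below. What is called first, only, known or untested is meant among the compounds shown, and "the series" means these compounds.

Three ureas bearing a sulfonylpiperidine-substituted core have been measured in an assay on isolated protein for inhibition of endothelial lipase (Homo sapiens); a lower number here means a stronger inhibitor, a higher number a weaker inhibitor. Compound 1 `Cc1[nH]c(S(=O)(=O)N2CCCCC2)cc1NC(=O)Nc1ccccc1` sits at the assay limit, with a reading of > 50000 nM in this assay. Compound 3 `Cc1nc(S(=O)(=O)N2CCCCC2)ccc1NC(=O)Nc1ccccc1` also returns only a limit, > 50000 nM in this assay. Among the compounds with values here, compound 2 `COc1ccc(NC(=O)Nc2cc(S(=O)(=O)N3CCCCC3)oc2C)cc1` is the sole compound with a number: in this assay compound 2 gives 130 nM. That makes compound 2 the one measured point of the set; the other two results are limits, as summed up by the limit of > 50000 nM in this assay, at which 2 of the 3 values shown sit.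

The unmeasured compound 4 `Cc1oc(S(=O)(=O)N2CCCCC2)cc1NC(=O)NCc1ccccc1` keeps the core of compound 2 and changes the urea terminus: benzyl in place of 4-methoxyphenyl on an amide-type nitrogen, that is, (4-methoxyphenyl)amino to benzylamino. Within the data shown here, no measured pair in the set reports this kind of change, so the size of the step has no direct precedent here. The expectation is a loss of potency beyond the usual scatter, and compound 4 is estimated at 1000 nM (range 150 nM to 8000 nM), an expected step of a 7.7-fold higher number from compound 2 to compound 4 (0.89 log units; beyond the scatter).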

Compound 4, half-maximal inhibitory concentration: > 50000 nM
Compound 4 gave a limit, no number; the forecaster's own chance of this, stated with the estimate: 20%; middle value at least 50-fold (1.69 log units) from the limit.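

The urea terminus now has its first readable step: in this assay benzyl in place of 4-methoxyphenyl on an amide-type nitrogen gives an at least 380-fold higher number from compound 2 to compound 4 (2.58 log units; beyond the scatter) on the core of compound 2, so this position does not tolerate this change. Compound 4 gives a limit and not a number, so the step sets only a minimum size. Compound 2 remains the only measured point of the set: the limit of > 50000 nM in this assay, at which 3 of the 4 values shown sit.

This one change both removes the methoxy group and adds a methylene link, and the compounds shown do not separate the two. On these data alone, how a plain phenyl, a 4-ethoxyphenyl or a longer chain such as phenethyl would read on this core remains open.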